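The compounds below may be only part of what the source reports. "The series", "measured", "known", "first", "only" and "open" are said of these compounds alone.

Working notes on the series. Three compounds have numbers in an assay on isolated protein for inhibition of serine protease 1 (Homo sapiens) (a higher number here means a weaker inhibitor, a lower number a stronger inhibitor), so far. Compound 1 `CC1(C)C2CC1[C@]1(C)OB([C@H](CCCN=C(N)N)NC(=O)c3ccc(-c4ccccc4)c(N)c3)O[C@@H]1C2` gives 4.7 nM in this assay. Compound 2 `COC(=O)NS(=O)(=O)c1ccccc1-c1ccc(C(=O)N[C@@H](CCCN=C(N)N)B2O[C@@H]3CC4CC(C4(C)C)[C@]3(C)O2)c(C)c1` gives 0.64 nM in this assay. Compound 3 `CC(C)(C)OC(=O)Nc1cccc(-c2cccc(C(=O)N[C@@H](CCCN=C(N)N)B3O[C@@H]4CC5CC(C5(C)C)[C@]4(C)O3)c2)c1` gives 35 nM in this assay, which is the highest number of the three; its nearest neighbour is compound 1 with a number beyond the scatter below it, and compound 2 stands further away still, also beyond the scatter. For the measured compounds named here, no two of the measured compounds differ in one place only, so no single step between measured compounds can be read off.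

Compound 4 `CC1(C)C2CC1[C@]1(C)OB([C@H](CCCN=C(N)N)NC(=O)c3cccc(-c4ccccc4)c3)O[C@@H]1C2` has not yet been measured. It differs from compound 3 in one place: hydrogen in place of (tert-butoxycarbonyl)amino on an aromatic carbon. The group that leaves is the largest single substituent on the outer ring of compound 3, and nothing in the measured set isolates its contribution.

The expectation for the step from compound 3 to compound 4 is a modest move to a lower number, a 2.3-fold lower number from compound 3 to compound 4 (0.37 log units; beyond the scatter), on the ground that compound 3 sits at 35 nM while the smaller-substituted compound 1 sits at 4.7 nM. Compound 4 is therefore estimated at 15 nM in this assay, within a range of 4 nM to 60 nM.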

Compound 4, inhibition constant: 7.4 nM
The estimate for compound 4 lay 2.0-fold (0.31 log units) above the measured number, and the stated range covers the measured number.
By their numbers in this assay, from the lowest: compound 2; then compounds 1 and 4 (each within the scatter of the next); then compound 3.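

In this assay, for the compounds shown here, replacing (tert-butoxycarbonyl)amino with hydrogen on this aromatic carbon gives a 4.7-fold lower number from compound 3 to compound 4 (0.67 log units; beyond the scatter), the first step that isolates one change. The group is therefore not needed at this position for inhibition of the protease: without any substituent there, compound 4 gives 7.4 nM, and carrying the group goes with a higher number beyond the scatter. No measurement at hand bears on what lies behind this step.

The compounds shown leave open whether the higher number of compound 3 belongs to the whole (tert-butoxycarbonyl)amino group or to its tert-butyl end, a question that a free amine or an acetamide on the same carbon would help to settle, while a methoxy group or a fluorine atom there would show whether any substituent at all is tolerated. Also open, on these data alone, is whether the step would carry over to compounds built like compound 1 or compound 2, which differ from compound 4 in more than one place.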